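This account rests on a few compounds, and the source may have more. Where it says the series, first, only, none or still open, it means among the compounds named here.

Of the compounds shown here, three have been tested in an ADME assay on HEK293 cells (Homo sapiens) for cytotoxicity, with a stated time of 72 h (a higher number here means that more compound is needed for the effect, a lower number that less compound is needed), and none of them gives a number. Compound 1 (`COc1ccc(-c2nc3ccccc3o2)cc1NC(=O)c1cc([N+](=O)[O-])ccc1Cl`) reads > 25000 nM, which is a limit of the assay. Compound 3 (`COc1cc(Cl)c(C(=O)Nc2cccc(-c3nc4ccccc4s3)c2)cc1[N+](=O)[O-]`) reads > 25000 nM, also a limit. Compound 2 (`COC(=O)C1CCN(c2cc(Cl)c(C(=O)Nc3cc(-c4nc5ccccc5s4)ccc3C)cc2[N+](=O)[O-])CC1`) reads > 25000 nM, likewise only a limit, so it cannot be ranked against the other two. All the tested compounds share a single reading: the limit of > 25000 nM in this assay, at which 3 of the 3 values shown sit.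

Compound 4 (`Cc1ccc(-c2nc3ccccc3s2)cc1NC(=O)c1cc([N+](=O)[O-])ccc1Cl`) differs from compound 2 in one place. Hydrogen stands in place of 4-(methoxycarbonyl)piperidin-1-yl on an aromatic carbon, ortho to a nitro group and meta to a chloro group (hydrogen in place of 4-(methoxycarbonyl)piperidin-1-yl on an aromatic carbon). For the measured compounds named here, no pair of tested compounds shows what a change of this kind does in this assay, since no measured step exists.

The expected step of a number no higher from compound 2 to compound 4 (the limit leaves the size open) is none beyond the scatter, in either direction. This expectation rests on compound 2, whose reading of > 25000 nM is a limit and gives no sign of a measurable effect. The assay is expected to report only a limit once more. For compound 4 the estimated value is 25000 nM, with an expected range from 12000 nM to 50000 nM.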

Compound 4, half-maximal effective concentration: > 14000 nM
Compound 4 ended at the assay's limit (the forecaster's own chance of this, stated with the estimate: 85%); the middle value is on the limit's open side.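

In this assay compound 4 gives > 14000 nM, which is a limit. Compound 2 gives > 25000 nM, also a limit. No step can be read between compound 2 and compound 4. The compounds shown leave open what hydrogen in place of 4-(methoxycarbonyl)piperidin-1-yl does in this assay, and at what concentration any of the four compounds would produce the effect.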